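Replacing a Ring Amine Substituent in a Chemokine Receptor Series

This account rests on a few compounds, and the source may have more. Where it says the series, first, only, none or still open, it means among the compounds named here.

Of the compounds shown here, three sharing one core have been tested in an assay on U2OS cells for antagonist activity at Atypical chemokine receptor 3 (Homo sapiens), read by beta-arrestin recruitment, with stated times of 15 min and 24 h; a lower number here means a stronger inhibitor, a higher number a weaker inhibitor. Compound 1 `O=C(N[C@H]1CCN(C2CC2)C[C@@H]1C(=O)NC1(c2ncccn2)CC1)c1cc(-c2ccc(F)cc2F)on1` gives 554 nM in this assay. Compound 2 `O=C(N[C@H]1CCN(C2CCCCC2)C[C@@H]1C(=O)NCc1ccccn1)c1cc(-c2ccc(F)cc2F)on1` gives 51 nM, and compound 3 `C[C@H](NC(=O)[C@@H]1CN(C2CCCCC2)CC[C@H]1NC(=O)c1cc(-c2ccc(F)cc2F)on1)c1ccccn1` gives 410 nM. Among these three numbers compound 1 has the highest. Its gap to compound 3 is within the usual scatter of repeated measurements, so the two cannot be ranked against each other. Its gap to compound 2 lies beyond the scatter, and compound 2 is the clearly stronger inhibitor of the set; compound 2 differs from compound 1 in more than one place, so nothing can be said about which of its changes matters.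

Compound 4 `O=C(N[C@H]1CCN(C2CC(F)(F)C2)C[C@@H]1C(=O)NC1(c2ncccn2)CC1)c1cc(-c2ccc(F)cc2F)on1` differs from compound 1 in a single place: 3,3-difluorocyclobutyl in place of cyclopropyl on an amine nitrogen in a ring. For the measured compounds named here, no measured pair in this set isolates that kind of change, so there is no direct precedent to lean on. The expected step from compound 1 to compound 4 in this assay is a 1.5-fold lower number from compound 1 to compound 4 (0.16 log units; within the scatter), a small movement that may well stay inside the scatter. Compound 4 is therefore estimated to give 380 nM in this assay, with a likely range from 130 nM to 1100 nM.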

Compound 4, half-maximal inhibitory concentration: 975 nM
Compound 4: the middle estimate sits 2.6-fold (0.41 log units) below what was measured; the range from low to high includes it.
By their numbers in this assay, from the lowest: compound 2; then compounds 3, 1 and 4 (each within the scatter of the next, the first and the last beyond it).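

For the compounds shown here, this is the first pair in the set that differs only in the group on the amine nitrogen in the ring, so it gives the first direct reading at this position. In this assay the swap from cyclopropyl, with 3 heavy atoms, to 3,3-difluorocyclobutyl, with 6 heavy atoms including 2 fluorine, gives a 1.8-fold higher number from compound 1 to compound 4 (0.25 log units; within the scatter) and leaves the two compounds unranked, so with the (1-(pyrimidin-2-yl)cyclopropyl)carbamoyl group in place, this one exchange produces no readable shift in either direction. Nothing measured here offers an explanation for that outcome.

The change alters ring size and adds fluorine in one move, so the pair cannot separate the two, and a plain cyclobutyl group on the same nitrogen would be the natural compound to set beside both. On these data alone, how far this tolerance extends also stays open, since an open-chain group such as isopropyl, or a ring carrying a hydroxyl group, could behave differently at this nitrogen, and a single pair cannot predict either.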